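This account rests on a few compounds, and the source may have more. Where it says the series, first, only, none or still open, it means among the compounds named here.

Compound 1, `CC(C)=CCn1cnc2c(Nc3cccc(Cl)c3)nc(N[C@H]3CC[C@H](N)CC3)nc21`, gives 3500 nM in a functional assay on K562 cells (Homo sapiens) for inhibition, read by fluorescence, with a stated time of 72 h; a lower number here means a stronger inhibitor of growth, a higher number a weaker inhibitor of growth.
Compound 2, `CC(C)=CCC/C(C)=C/Cn1cnc2c(Nc3cccc(Cl)c3)nc(N[C@H]3CC[C@H](N)CC3)nc21`, gives 2200 nM in this assay.
Compound 3, `COc1ccc(Cn2cnc3c(Nc4cccc(Cl)c4)nc(N[C@H]4CC[C@H](N)CC4)nc32)cc1`, gives 2800 nM in this assay.

All three compounds share one core and differ only in the group carried on a saturated chain carbon bound to an aromatic nitrogen. Exchanging that group made little difference: a 1.6-fold lower number from compound 1 to compound 2 (0.20 log units; within the scatter), a 1.3-fold lower number from compound 1 to compound 3 (0.10 log units; within the scatter) and a 1.3-fold higher number from compound 2 to compound 3 (0.10 log units; within the scatter) all lie within the scatter of repeated measurements. Compound 3 therefore stands second highest of the three numbers, but its gaps to compound 1 and compound 2 are both too small to rank it with confidence.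

Compound 4, `N[C@H]1CC[C@H](Nc2nc(Nc3cccc(Cl)c3)c3ncn(Cc4ccccc4)c3n2)CC1`, is the next step from compound 3. The change is hydrogen in place of methoxy on an aromatic carbon. Going by the values given here, none of the measured steps concerns this part of the molecule; every one of them altered the group on the saturated chain carbon bound to the aromatic nitrogen instead. What the measured steps do show is that small changes at the edge of this series have so far stayed within the scatter. On that basis the expected step is no change at the digits printed from compound 3 to compound 4 (within the scatter), with no change beyond the scatter anticipated. Compound 4 is expected to give about 2800 nM in this assay, within a range of 1400 nM to 5600 nM.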

Compound 4, concentration for 50% growth inhibition: 3000 nM
Beside the measured number, compound 4's estimate is 1.1-fold (0.03 log units) below it; low and high end bracket the measured number.
By their numbers in this assay, from the lowest: compounds 2, 3, 4 and 1 (each within the scatter of the next).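

In this assay, replacing methoxy with hydrogen on the aromatic carbon para to a large group gives a 1.1-fold higher number from compound 3 to compound 4 (0.03 log units; within the scatter), so this first change on the ring itself, 4-methoxyphenyl to phenyl, does not separate the two compounds. With plain phenyl in the side group, the comparisons with the two chain-bearing compounds also stay small, at a 1.4-fold higher number from compound 2 to compound 4 (0.13 log units; within the scatter) and a 1.2-fold lower number from compound 1 to compound 4 (0.07 log units; within the scatter), which means that phenyl, 2,6-dimethylhepta-1,5-dien-1-yl and 2-methylprop-1-en-1-yl cannot be told apart in this measurement. No further measurement is available that would explain this result.

Still open is whether an amine, a carboxylic acid or a longer chain at this same place on the phenyl ring would move the number beyond the scatter, since methoxy and hydrogen are the only two groups shown there. Also open, from the compounds shown here alone, is what a change elsewhere on the molecule would do, as all four compounds keep the rest of the shared core the same and differ only in the group on the saturated chain carbon bound to an aromatic nitrogen.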